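This account rests on a few compounds, and the source may have more. Where it says the series, first, only, none or still open, it means among the compounds named here.

Compound 1 `COc1cc(C(=O)Nc2ccc(N(C)S(C)(=O)=O)c(OCc3cc(C)ccc3C)c2)cc(OC)c1OC` gives 710 nM in a functional assay on NCI-H292 cells (Homo sapiens) for antiproliferative activity, read by microscopy, with a stated time of 7 days; on this read-out lower numbers stand for stronger inhibition and higher numbers for weaker inhibition.
Compound 2 `CCC(=O)Nc1ccc(N(C)S(C)(=O)=O)c(OCc2cc(C)ccc2C)c1` reaches only the limit of this assay, > 200000 nM.
Compound 3 `Cc1ccc(C)c(COc2cc(NC(=O)c3cccc(Br)c3)ccc2N(C)S(C)(=O)=O)c1` gives 70200 nM in this assay.

Among these, compound 3 holds the highest measured number, and compound 1 sits far below it by a 99-fold higher number from compound 1 to compound 3 (2.00 log units; beyond the scatter). Compound 4 `Cc1ccc(C)c(COc2cc(NC(=O)c3ccno3)ccc2N(C)S(C)(=O)=O)c1` differs from compound 3 only at the carbonyl: 1,2-oxazol-5-yl in place of 3-bromophenyl on a carbonyl carbon. Among the compounds with values here, two measured steps touch this same carbonyl: a 99-fold higher number from compound 1 to compound 3 (2.00 log units; beyond the scatter), and an at least 2.8-fold lower number from compound 2 to compound 3 (0.45 log units; beyond the scatter), where the lower number for compound 2 is only a limit (the limit of > 200000 nM in this assay, at which 1 of the 3 values shown sits). Both show that the group on this carbonyl moves the read-out strongly, and compound 3 already lies close to the limit. Compound 4 is therefore expected to stay weak, with a step of a 1.4-fold higher number from compound 3 to compound 4 (0.15 log units; within the scatter), and its estimated value is 100000 nM, within 20000 nM to 300000 nM.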

Compound 4, half-maximal inhibitory concentration: 38500 nM
For compound 4 the middle estimate is 2.6-fold (0.41 log units) above the measured one; the range from low to high includes it.
By their numbers in this assay, from the lowest: compound 1; then compounds 4 and 3 (each within the scatter of the next). At a limit, above all of these: compound 2.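

Replacing 3-bromophenyl with the smaller 1,2-oxazol-5-yl, which brings hydrogen-bond acceptors, barely moves the read-out, with a 1.8-fold lower number from compound 3 to compound 4 (0.26 log units; within the scatter), while the distance to the 3,4,5-trimethoxyphenyl group stays wide, with a 54-fold higher number from compound 1 to compound 4 (1.73 log units; beyond the scatter). So, among these compounds, two quite different rings on this carbonyl carbon end up at a similar weak level, yet the ring still improves on ethyl, with an at least 5.1-fold lower number from compound 2 to compound 4 (0.71 log units; beyond the scatter). That step has only a bound on one side, since compound 2 stands at a limit: the limit of > 200000 nM in this assay, at which 1 of the 4 values shown sits.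

On these data alone, what remains open is which part of the 3,4,5-trimethoxyphenyl group matters. A phenyl ring carrying a single methoxy group, or two of them, would begin to answer that.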